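Methyl on a Ring Nitrogen: Expected Cytotoxicity of Compound 4

This account rests on a few compounds, and the source may have more. Where it says the series, first, only, none or still open, it means among the compounds named here.

Compound 1 `COc1ccc(Nc2ncc3c(n2)NCC(=O)N3)cc1` in a functional assay on MDA-MB-231 cells (Homo sapiens) for cytotoxicity, read by MTT assay, with a stated time of 48 h (on this read-out lower numbers stand for stronger inhibition and higher numbers for weaker inhibition), gives > 100000 nM, which is a limit of the assay.
Compound 2 `COc1cccc(Nc2ncc3c(n2)NCC(=O)N3)c1` in this assay gives 93200 nM.
Compound 3 `CN1CC(=O)Nc2cnc(Nc3ccc(Cl)cc3)nc21` in this assay gives > 100000 nM, which is a limit of the assay.

Within the data shown here, compound 2 stands as the only measurement that is a number; the two other measurements sit at the limit of > 100000 nM in this assay, at which 2 of the 3 values shown sit. Compound 4 `COc1cccc(Nc2ncc3c(n2)N(C)CC(=O)N3)c1` differs from compound 2 by methyl in place of hydrogen on a nitrogen on an aromatic ring in a ring. Among the measured compounds shown here, no measured pair isolates this change. Compound 3 carries the same methyl on that nitrogen, together with a different aniline, and reports only a limit. Compound 2, without the methyl, gives a number near that limit. The step in this assay is therefore expected to be none beyond the scatter. Compound 4 is estimated at 110000 nM, with a range from 40000 nM to 300000 nM, which would mean an expected step of a 1.2-fold higher number from compound 2 to compound 4 (0.07 log units; within the scatter).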

Compound 4, half-maximal inhibitory concentration: > 100000 nM
Compound 4 was reported as a limit; the forecaster's own chance of this, stated with the estimate: 55%; the middle value is on the limit's open side.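

Among these compounds, for the first time a pair isolates methyl in place of hydrogen on this nitrogen, and in this assay it gives an at least 1.0-fold higher number from compound 2 to compound 4 (0.03 log units; that floor lies within the scatter). That step is only a floor, as it rests on a limit for compound 4, so the true size of the change cannot be read. The methyl gives no sign of stronger inhibition at this position, and the read-out leaves little room to see any weakening: the limit of > 100000 nM in this assay, at which 3 of the 4 values shown sit.

Going by these compounds, whether the methyl weakens inhibition at all stays open. So does whether an ethyl group or a longer chain ending in an amine on this nitrogen would give a clear number.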